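Notes on the aryl amide series, compound 1 to compound 4

The source may hold more compounds than are shown below. What is called first, only, known or untested is meant among the compounds shown, and "the series" means these compounds.

Compound 1 `COc1cc(N(C)C(=O)c2cccc(F)c2)cc(OC)c1OC` carries a tertiary amide on the shared core. In a functional assay on Daoy cells (Homo sapiens) for cytotoxicity, read by MTT assay, with a stated time of 72 h (a lower number here means a stronger inhibitor, a higher number a weaker inhibitor), compound 1 gives >= 125000 nM, which is a limit of the assay and not a number. Compound 2 `COc1ccc([S+]([O-])N(C)c2cc(OC)c(OC)c(OC)c2)cc1` in this assay gives >= 125000 nM, also a limit. Compound 3 `COc1cc(NC(=O)Nc2cccc([N+](=O)[O-])c2)cc(OC)c1OC`, a urea, gives 82500 nM in this assay. Compound 1 therefore stands at the limit of >= 125000 nM in this assay, at which 2 of the 3 values shown sit; how it compares with compound 3 cannot be read, as only a limit is known for compound 1.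

Compound 4 `COc1ccc(C(=O)N(C)c2cc(OC)c(OC)c(OC)c2)cc1` has not yet been measured in this assay. It differs from compound 1 by 4-methoxyphenyl in place of 3-fluorophenyl on a carbonyl carbon. Within the data shown here, no step between two measured compounds is available in this set, so the size of this change has no measured precedent here. The step from compound 1 to compound 4 is expected to be a number no higher from compound 1 to compound 4 (the limit leaves the size open), that is, nothing beyond the usual scatter, and a limit rather than a number is the likelier outcome. For compound 4 the estimate in this assay is 125000 nM, with a range from 50000 nM to 300000 nM.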

Compound 4, half-maximal inhibitory concentration: >= 125000 nM
Compound 4 was reported as a limit (the forecaster's own chance of this, stated with the estimate: 65%); the middle value sits exactly at the limit.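

Compound 1 and compound 4 are both reported only as limits in this assay, so the step between them cannot be read. Most of the set sits there: the limit of >= 125000 nM in this assay, at which 3 of the 4 values shown sit. The compounds shown leave open whether any group on that carbonyl carbon would give a number rather than a limit in this assay.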